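Ethyl added to the piperidine of compound 1

The source may report more compounds than this note shows. Statements on the series, on what has been measured and on what is new or still open speak of the compounds shown alone.

Measured in an ADME assay on cells (Hepatocyte, Rattus norvegicus, strain Wistar) for pharmacokinetics, read by LC-MS, with a stated time of 90 min, tested at 1 uM; a higher number here means faster removal of the compound, a lower number slower removal:
- compound 1 `COc1cc(C(=O)N2CCC(O)C(C)C2)cc2nc(NCc3cccc(Cl)c3)oc12`: 45 mL/min/kg
- compound 2 `COc1cc(C(=O)N2CCC(O)C(C)C2)cc2nc(NCc3cc(Cl)ccn3)oc12`: 14.3 mL/min/kg
- compound 3 `COc1cc(C(=O)N2CCC(O)C(C)C2)cc2nc(NC3(c4cccc(Cl)c4)CC3)oc12`: 46.7 mL/min/kg

The numbers place compound 1 in the upper pair of these three: there is a 1.0-fold higher number from compound 1 to compound 3 (0.02 log units; within the scatter), but a 3.1-fold lower number from compound 1 to compound 2 (0.50 log units; beyond the scatter). The next compound, compound 4 `CCC1CC(O)C(C)CN1C(=O)c1cc(OC)c2oc(NCc3cccc(Cl)c3)nc2c1`, keeps the 3-chlorobenzyl group of compound 1 and changes the other end of the molecule. It carries ethyl in place of hydrogen on a saturated ring carbon, so that 4-hydroxy-3-methylpiperidin-1-yl becomes 2-ethyl-4-hydroxy-5-methylpiperidin-1-yl. For the measured compounds named here, no measured step touches this ring, since all of them alter the group on a nitrogen on an aromatic ring. They bear on the question only indirectly. Going by the values given here, the nearest guide is the carbon-adding change in a 1.0-fold higher number from compound 1 to compound 3 (0.02 log units; within the scatter), while the pyridine change in a 3.1-fold lower number from compound 1 to compound 2 (0.50 log units; beyond the scatter) has no counterpart here. No step beyond the scatter is therefore expected in this assay. The expected change is a 1.1-fold higher number from compound 1 to compound 4 (0.05 log units; within the scatter). Compound 4 is estimated at 50 mL/min/kg, with an expected range of 28 mL/min/kg to 90 mL/min/kg.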

Compound 4, clearance: 61.7 mL/min/kg
Beside the measured number, compound 4's estimate is 1.2-fold (0.09 log units) below it, within the range that was stated.
By their numbers in this assay, from the lowest: compound 2; then compounds 1, 3 and 4 (each within the scatter of the next).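

The ethyl group sits on a saturated ring carbon next to the ring nitrogen, the first change shown at this end of the molecule, and in this assay it gives a 1.4-fold higher number from compound 1 to compound 4 (0.14 log units; within the scatter) and so stays within the scatter. This position therefore accepts ethyl in place of hydrogen without a clear shift in clearance, although the ring now carries a new group next to the ring nitrogen. The step at the other end of the molecule, a 3.1-fold lower number from compound 1 to compound 2 (0.50 log units; beyond the scatter), remains the larger one, and no evidence is available to explain either result.

On these data alone, whether a longer chain such as propyl, or a carboxylic acid or an amine, would be tolerated on this ring carbon stays open. As far as these compounds go, it is also open whether ethyl here would give a similar result with the 4-chloropyridin-2-yl group of compound 2.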